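Tolerated Concentration of Compound 4, Estimated from Compound 1

The source may report more compounds than this note shows. Statements on the series, on what has been measured and on what is new or still open speak of the compounds shown alone.

Compound 1, `CCCC(=O)OCSc1ccccc1C(=O)N[C@@H]1CCC[C@@H]1C(N)=O`, gives 90 uM.
Compound 2, `CCCC(=O)OC[Se]c1ccccc1C(=O)NCCC(N)=O`, gives 10.5 uM.
Compound 3, `CCCC(=O)OCSc1ccccc1C(=O)N(C)CC(N)=O`, gives 55.3 uM.

These three values come from an ADME assay on CEM-SS cells (Homo sapiens) for cytotoxicity, read by XTT assay, with a stated time of 6 days; a lower number here means that less compound is tolerated, a higher number that more compound is tolerated. Compound 1 stands at the highest of the three numbers. Its nearest neighbour is compound 3, whose number lies within the usual scatter of repeated measurements, so the two cannot be told apart on these data alone. Compound 2 lies furthest away, with a number well beyond the scatter, meaning that less of compound 2 is tolerated than of compound 1.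

The step of interest leads from compound 1 to compound 4, `CCCC(=O)OCSc1ccccc1C(=O)NCC(=O)NCC(N)=O`, which has not yet been measured in this assay. The difference between the two structures is ((carbamoylmethyl)carbamoyl)methyl in place of 2-carbamoylcyclopentyl on an amide-type nitrogen. Going by the values given here, no measured pair in this set shows the effect of such a change, so the size of the step has to be guessed. The expectation is for little movement, a step of a 1.1-fold lower number from compound 1 to compound 4 (0.05 log units; within the scatter) that most likely stays within the scatter. Compound 4 is therefore estimated at 80 uM, with a range from 35 uM to 160 uM.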

Compound 4, half-maximal toxic concentration: > 100 uM
Compound 4 gave a limit, no number; the forecaster's own chance of this, stated with the estimate: 20%; middle value at least 1.2-fold (0.09 log units) from the limit.
By their numbers in this assay, from the lowest: compound 2; then compounds 3 and 1 (each within the scatter of the next). At a limit, above all of these: compound 4.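

In this assay compound 4 gives > 100 uM, which is a limit of the assay and not a number. On this amide-type nitrogen, swapping 2-carbamoylcyclopentyl for ((carbamoylmethyl)carbamoyl)methyl, a group with no ring and no defined stereocentres, gives an at least 1.1-fold higher number from compound 1 to compound 4 (0.04 log units; that floor lies within the scatter), so the five-membered ring can go without any sign of a lower tolerated concentration. The true size of this step cannot be read, and so a real rise in the tolerated concentration is not established, as the reading ends at a limit: the limit of > 100 uM in this assay, at which 1 of the 4 values shown sits.

The compounds shown leave open what a carboxylic acid in place of the final carbamoyl group, or an amine there, would do. They also leave open whether a longer chain on this nitrogen would behave like ((carbamoylmethyl)carbamoyl)methyl.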